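Fluoro for hydrogen on the benzylamide of compound 2

The source may hold more compounds than are shown below. What is called first, only, known or untested is meant among the compounds shown, and "the series" means these compounds.

Measured compounds:
compound 1 `CN(C)CCCCN(C)C1=Nc2ccccc2C(CC(=O)NCc2ccccc2)N1c1ccc(-c2ccccc2)cc1`: 310 nM
compound 2 `CN(C)CCN1CCN(C2=Nc3ccccc3C(CC(=O)NCc3ccccc3)N2c2ccc(-c3ccccc3)cc2)CC1`: "not determined" (no result reported)

In an assay on HEK293 cells for inhibition of Voltage-dependent T-type calcium channel subunit alpha-1G (Homo sapiens), read by patch clamp (on this read-out higher numbers stand for weaker inhibition and lower numbers for stronger inhibition), compound 1 gives 310 nM. Compound 2 `CN(C)CCN1CCN(C2=Nc3ccccc3C(CC(=O)NCc3ccccc3)N2c2ccc(-c3ccccc3)cc2)CC1` shares the core of compound 1 but differs elsewhere in the structure, and for compound 2 this assay gives "not determined" (no result reported), so compound 2 stands nowhere on the figures shown; the only measured point is compound 1.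

Compound 3 `CN(C)CCN1CCN(C2=Nc3ccccc3C(CC(=O)NCc3ccc(F)cc3)N2c2ccc(-c3ccccc3)cc2)CC1` is the unmeasured partner of compound 2. The change is fluoro in place of hydrogen on an aromatic carbon, placed on a six-membered aromatic ring of carbon only, para to a large group. Among the compounds with values here, no step between measured compounds is known here, and nothing ties compound 2 to a value, so the step in this assay from compound 2 to compound 3 is expected to be small, in no particular direction, and not beyond the scatter. Compound 3 is therefore estimated at about 300 nM, in the range 70 nM to 1500 nM.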

Compound 3, half-maximal inhibitory concentration: 320 nM
The estimate for compound 3 lay 1.1-fold (0.03 log units) below the measured number, and the stated range covers the measured number.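

No step from compound 2 to compound 3 can be read: in this assay only compound 3 of the pair has a number, 320 nM as shown. Going by these compounds, what fluoro in place of hydrogen does on the benzylamide therefore stays open. No evidence shown bears on this result.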